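The compounds below may be only part of what the source reports. "The series", "measured", "known", "first", "only" and "open" are said of these compounds alone.

Compound 1 `c1cc(OCc2ccc3ccccc3n2)cc(OCc2nn[nH]n2)c1` carries a (2H-tetrazol-5-yl)methoxy group on the shared core. In an assay on isolated protein for binding affinity to cysteinyl leukotriene receptor 1 (Cavia porcellus) (on this read-out lower numbers stand for stronger inhibition and higher numbers for weaker inhibition), compound 1 gives 85 nM, the highest of the three numbers in hand. Compound 2 `c1ccc2nc(COc3ccc(SCCCc4nnn[nH]4)cc3)ccc2c1` gives 31 nM and compound 3 `c1ccc2nc(COc3ccc(OCCCc4nnn[nH]4)cc3)ccc2c1` gives 69 nM in this assay; compound 1 and compound 3 lie within the scatter of each other, while compound 2 stands beyond the scatter from both. Within the data shown here, the only step between measured compounds is a 2.2-fold higher number from compound 2 to compound 3 (0.35 log units; beyond the scatter), an exchange of sulfur for oxygen in the chain that joins the ring with four hetero atoms to the core; the tetrazole itself is kept in every measured compound.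

Compound 4 `CCOC(=O)CCCOc1cccc(OCc2ccc3ccccc3n2)c1` differs from compound 1 by 2-(ethoxycarbonyl)ethyl in place of 2H-tetrazol-5-yl on a saturated chain carbon bound to an oxygen on an aromatic ring. Among the measured compounds shown here, no measured pair covers this exchange: the step from compound 2 to compound 3 concerns the linker alone and gives no reading on what removing the tetrazole and putting in an ester does. Any expectation here therefore rests on the structural change alone and must carry a wide range. For compound 4 the expected step is an 8.2-fold higher number from compound 1 to compound 4 (0.92 log units; beyond the scatter), toward a higher number. Compound 4 is estimated at 700 nM, within 120 nM to 4000 nM.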

Compound 4, inhibition constant: 160 nM
Compound 4: middle estimate off by 4.4-fold (0.64 log units), on the high side, within the range that was stated.
By their numbers in this assay, from the lowest: compound 2; then compounds 3, 1 and 4 (each within the scatter of the next, the first and the last beyond it).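

In this assay, 2-(ethoxycarbonyl)ethyl in place of 2H-tetrazol-5-yl, on a saturated chain carbon bound to an oxygen on an aromatic ring, gives a 1.9-fold higher number from compound 1 to compound 4 (0.27 log units; within the scatter). Among these compounds, this is the first reading on the tetrazole itself, since the earlier step concerned only the linker: at this place, in this pair, an open chain ester with no ring and 0 hydrogen-bond donors stands within the scatter of a group with an aromatic ring and 1 hydrogen-bond donor. So the tetrazole is not shown to be needed on this core in this read-out, and nothing at hand gives a reason for that result.

The compounds shown leave open how a carboxylic acid in place of the ethyl ester, or a shorter or longer chain carrying the ester, would read at this place. They also leave open whether sulfur in place of the oxygen bound to the aromatic ring would matter in the ester series as it does in the tetrazole pair, where the exchange reads as a 2.2-fold higher number from compound 2 to compound 3 (0.35 log units; beyond the scatter).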